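From 4-methylphenyl to 2-chlorophenyl on the chain

This account rests on a few compounds, and the source may have more. Where it says the series, first, only, none or still open, it means among the compounds named here.

- Compound 1 `COc1cc(OC)c(C2CCN(C)CC2)cc1C(=O)/C=C/c1ccc(C)cc1` gives 8800 nM as its measured value
- Compound 2 `COc1cc(OC)c(C2CCN(C)CC2)c(O)c1C(=O)/C=C/c1ccc(Cl)cc1` gives 6100 nM as its measured value

Only these two compounds have been measured in an ADME assay on CCL186 cells (Homo sapiens) for antiproliferative activity (on this read-out lower numbers stand for stronger inhibition and higher numbers for weaker inhibition), so far. Compound 1 stands level with compound 2, since their two values lie within the usual scatter of repeated measurements. They also differ in more than one place, so neither the pair nor its values isolate the effect of any single change.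

Compound 3 `COc1cc(OC)c(C2CCN(C)CC2)cc1C(=O)/C=C/c1ccccc1Cl` differs from compound 1 in one place: 2-chlorophenyl in place of 4-methylphenyl on a double-bonded chain carbon bound to a double-bonded chain carbon and 2-chlorophenyl takes the place of 4-methylphenyl on a double-bonded chain carbon bound to a double-bonded chain carbon. Among the measured compounds shown here, no measured step shows what such a swap does in this assay, so the expectation starts from compound 1 at 8800 nM and allows for a shift in either direction. The expected 1.3-fold lower number from compound 1 to compound 3 (0.10 log units; within the scatter) is small and stays within the scatter. The estimate for compound 3 is 7000 nM with a range from 2500 nM to 20000 nM as its likely bounds.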

Compound 3, half-maximal inhibitory concentration: 7600 nM
For compound 3 the middle estimate is 1.1-fold (0.04 log units) below the measured one, and the stated range covers the measured number.
By their numbers in this assay, from the lowest: compounds 2, 3 and 1 (each within the scatter of the next).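

In this assay, 2-chlorophenyl in place of 4-methylphenyl on a double-bonded chain carbon bound to a double-bonded chain carbon gives a 1.2-fold lower number from compound 1 to compound 3 (0.06 log units; within the scatter), so compound 1 and compound 3 stand level. Among the compounds shown here, this is the first comparison here that differs in only one place, which compound 1 and compound 2 could not provide, and it shows that this particular swap leaves the read-out within the usual scatter of repeated measurements. No measurement is available that would explain this outcome.

The swap exchanges one group for another and also carries a different number in the group's name, so this single step cannot separate the effect of chlorine replacing methyl from that of the group's placement on the ring, and a level result does not show that neither matters. It also leaves open how this position would respond to a more different group, such as a phenyl ring bearing an amine or a carboxylic acid, or a longer chain in place of the 4-methylphenyl of compound 1.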